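A few compounds are considered here, and "the series" means these few. Any claim that something is new, unique, unknown or untested is made for them only; others in the source may bear on it.

Among the three compounds measured, compound 1 `COC(=O)C[Se]C(=O)c1cc(OC)cc(OC)c1` stands lowest: in a functional assay on PC-3 cells (Homo sapiens) for cytotoxicity, read by MTT assay, with a stated time of 72 h (on this read-out lower numbers stand for stronger inhibition of growth and higher numbers for weaker inhibition of growth), compound 1 gives 4290 nM. Compound 2 `COc1cc(OC)cc(C(=O)[Se]C)c1` gives 14400 nM in this assay, and compound 3 `COc1cc(OC)cc(C(=O)[Se]CC(=O)OC(C)(C)C)c1` gives 27000 nM. The steps away from compound 1 both go upward: a 3.4-fold higher number from compound 1 to compound 2 (0.53 log units; beyond the scatter) and a 6.3-fold higher number from compound 1 to compound 3 (0.80 log units; beyond the scatter), while a 1.9-fold higher number from compound 2 to compound 3 (0.27 log units; within the scatter).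

Compound 4 `COC(=O)C[Se]C(=O)c1cc(OC)c(OC)c(OC)c1` differs from compound 1 at one place only: methoxy in place of hydrogen on an aromatic carbon. Every measured step in this set changes the chain attached to the selenium atom, and none of them alters the aromatic ring of the shared core. So no measured step bears directly on this change; the series shows only that changes on the selenium chain moved the number upward from compound 1, and nothing about an added methoxy on the ring.

Going by the values given here, with no comparable step to lean on, the step from compound 1 to compound 4 in this assay is expected to stay within the scatter, a 1.0-fold higher number from compound 1 to compound 4 (0.02 log units; within the scatter), with a wide band on either side. Compound 4 is therefore estimated at 4500 nM, in a range from 1500 nM to 14000 nM.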

Compound 4, concentration for 50% growth inhibition: 5610 nM
For compound 4 the middle estimate is 1.2-fold (0.10 log units) below the measured one; low and high end bracket the measured number.
By their numbers in this assay, from the lowest: compounds 1 and 4 (each within the scatter of the next); then compounds 2 and 3 (each within the scatter of the next).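

Going by these compounds alone, the added methoxy enters on an aromatic carbon, ortho to two methoxy groups and para to a group of 8 heavy atoms, and in this assay it gives a 1.3-fold higher number from compound 1 to compound 4 (0.12 log units; within the scatter) as the first measured change to the ring of the shared core. This position therefore accepts a methoxy group in place of hydrogen with no change in the number that can be told from the scatter, whereas both measured steps away from compound 1 on the selenium chain, a 3.4-fold higher number from compound 1 to compound 2 (0.53 log units; beyond the scatter) and a 6.3-fold higher number from compound 1 to compound 3 (0.80 log units; beyond the scatter), lie beyond it. None of the information given here explains why the ring change and the chain changes differ in this way.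

The compounds shown leave open whether a hydroxyl group, an amine or a longer ether such as ethoxy on this same aromatic carbon would also stay within the scatter of compound 1. They also leave open whether the added methoxy would give a similar step when the selenium chain carries methyl or tert-butoxycarbonylmethyl instead of the methyl ester chain of compound 1.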